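Chlorine placement on the phenyl group: compound 2 to compound 3

The source may hold more compounds than are shown below. What is called first, only, known or untested is meant among the compounds shown, and "the series" means these compounds.

Going by the values given here, in a functional assay on MCF7 cells (Homo sapiens) for antiproliferative activity, read by MTT assay, with a stated time of 48 h (on this read-out lower numbers stand for stronger inhibition and higher numbers for weaker inhibition), compound 1 `CC(=O)N1N=C(c2ccc3ccccc3c2)OC1c1cccc(Br)c1` gives 2.34 ug/mL and compound 2 `CC(=O)N1N=C(c2ccc3ccccc3c2)OC1c1ccccc1Cl` gives 2.36 ug/mL so compound 2 stands level with its only measured neighbour, within the scatter. The next compound, compound 3 `CC(=O)N1N=C(c2ccc3ccccc3c2)OC1c1ccc(Cl)cc1`, has the same atoms joined differently: 4-chlorophenyl in place of 2-chlorophenyl on a saturated ring carbon with 4-chlorophenyl in place of 2-chlorophenyl on a saturated ring carbon, and the shared core stays as it is.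

Among the compounds with values here, the one measured step that bears on this is a 1.0-fold higher number from compound 1 to compound 2 (0.00 log units; within the scatter) for 2-chlorophenyl in place of 3-bromophenyl at that same carbon. Within the data shown here, it lies within the scatter, yet it is only a single step, and no measured compound carries 4-chlorophenyl, so the evidence is thin. On that step alone, no move beyond the scatter is expected in this assay and neither direction is favoured. The estimated move is a 1.0-fold higher number from compound 2 to compound 3 (0.01 log units; within the scatter) on present data. For compound 3 the expected value is 2.4 ug/mL with an estimated range from 1.2 ug/mL to 4.8 ug/mL in these notes.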

Compound 3, half-maximal inhibitory concentration: 2.63 ug/mL
Compound 3: middle estimate off by 1.1-fold (0.04 log units), on the low side; the measured number falls inside the stated range.
By their numbers in this assay, from the lowest: compounds 1, 2 and 3 (each within the scatter of the next).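

In this assay, going by these compounds alone, 4-chlorophenyl in place of 2-chlorophenyl on the saturated ring carbon gives a 1.1-fold higher number from compound 2 to compound 3 (0.05 log units; within the scatter) and provides the first comparison of one halogen placed differently on the phenyl group at this carbon; within this pair, the read-out does not separate the two placements. The other new step, 4-chlorophenyl in place of 3-bromophenyl, gives a 1.1-fold higher number from compound 1 to compound 3 (0.05 log units; within the scatter) and so adds a comparison in which both the halogen and its placement differ, again without separating the two groups. No measured information accompanies these results to account for the level values across this small set.

All three groups at this carbon are halogen-bearing phenyl groups, so the compounds shown leave open whether a phenyl group carrying an amine or a carboxylic acid, or a longer chain in place of the phenyl group, would give a number beyond the scatter. They also leave open how far the acetyl group on the ring atom and the large group elsewhere on the shared core contribute to the values, as both stay the same in all three compounds.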